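A few compounds are considered here, and "the series" means these few. Any claim that something is new, unique, unknown or untested is made for them only; others in the source may bear on it.

Measured compounds:
compound 1, `Nc1cc(N)c2nc(-c3ccccc3)c(Oc3ccc(Cl)c(Cl)c3)nc2c1`: 30200 nM
compound 2, `CCOC(=O)[C@H](CCC(=O)O)NC(=O)c1ccc(CNc2nc3cc(N)cc(N)c3nc2-c2ccccc2)cc1`: < 100000 nM
compound 3, `CCOC(=O)[C@H](CCC(=O)O)NC(=O)c1ccc(Sc2nc3cc(N)cc(N)c3nc2-c2ccccc2)cc1`: < 100000 nM

Of the compounds shown here, three sharing one core have been tested in a functional assay on SW-620 cells (Homo sapiens) for inhibition, read by sulforhodamine B assay, with a stated time of 48 h; a higher number here means a weaker inhibitor of growth, a lower number a stronger inhibitor of growth. Among the compounds with values here, compound 1 gives 30200 nM, and this is the only number among the three. For compound 2 the result is a limit of the assay, < 100000 nM. For compound 3 the result is likewise a limit, < 100000 nM. Within the data shown here, compound 1 thus stands alone as the single measured value, with the other two resting at the limit of < 100000 nM in this assay, at which 2 of the 3 values shown sit.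

Compound 4, `Nc1cc(N)c2nc(-c3ccccc3)c(Sc3ccc(F)cc3)nc2c1`, has not yet been measured in this assay. It differs from compound 1 in one place: (4-fluorophenyl)sulfanyl in place of 3,4-dichlorophenoxy on an aromatic carbon, on an aromatic carbon of the six-membered ring with two nitrogens that is part of the fused system, next to the ring nitrogen and ortho to the phenyl group.

Among the measured compounds shown here, no step between measured compounds is available to guide the direction, since compounds 2 and 3 report only limits. The change keeps an aromatic ring of about the same size attached through a single linking atom, so the expected step from compound 1 to compound 4 is a 1.2-fold lower number from compound 1 to compound 4 (0.08 log units; within the scatter), a shift not clearly beyond the scatter in either direction. Compound 4 is therefore estimated at 25000 nM, within a range of 6000 nM to 90000 nM.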

Compound 4, concentration for total growth inhibition: 50100 nM
Estimate against measurement, compound 4: 2.0-fold (0.30 log units) below; the measured number falls inside the stated range.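

In this assay, within the data shown here, replacing 3,4-dichlorophenoxy with (4-fluorophenyl)sulfanyl on this aromatic carbon gives the first step that can be read, a 1.7-fold higher number from compound 1 to compound 4 (0.22 log units; within the scatter). The linking oxygen gives way to sulfur and the two chlorine atoms to one fluorine, yet the read-out stays within the usual scatter, so this exchange does not separate compound 1 from compound 4. Compound 2 and compound 3 could not show this, each reporting only a limit, which leaves their steps unreadable: the limit of < 100000 nM in this assay, at which 2 of the 4 values shown sit.

The compounds shown leave open what the linking atom and the halogens each contribute alone, for both changed together in this single step. They also leave open how this position would read with an amine or a carboxylic acid in place of the aromatic ring and its link.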